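A few compounds are considered here, and "the series" means these few. Any claim that something is new, unique, unknown or untested is made for them only; others in the source may bear on it.

The measured compounds and their values in an assay on isolated protein for inhibition of Aromatase (Homo sapiens), read by fluorescence and colorimetric assay, with a stated time of 30 min; a higher number here means a weaker inhibitor, a lower number a stronger inhibitor:

- Compound 1 `N#Cc1ccc(C(c2ccc(C#N)cc2)n2cc(C3CCCCC3)nn2)cc1`: in this assay compound 1 gives 19300 nM
- Compound 2 `N#Cc1ccc(OCc2cn(C(c3ccc(C#N)cc3)c3ccc(C#N)cc3)nn2)cc1`: in this assay compound 2 gives 4640 nM
- Compound 3 `N#Cc1ccc(C(c2ccc(C#N)cc2)n2cc(COc3ccc([N+](=O)[O-])cc3)nn2)cc1`: in this assay compound 3 gives 7730 nM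

Among these three numbers compound 3 stands second highest. Its nearest neighbour is compound 2, where the change is a 1.7-fold higher number from compound 2 to compound 3 (0.22 log units; within the scatter); its furthest is compound 1, with a 2.5-fold lower number from compound 1 to compound 3 (0.40 log units; beyond the scatter). The other measured step, a 4.2-fold lower number from compound 1 to compound 2 (0.62 log units; beyond the scatter), likewise concerns only the group on the aromatic carbon of the shared core.

Compound 4 `N#Cc1ccc(Cn2cc(COc3ccc([N+](=O)[O-])cc3)nn2)cc1` differs from compound 3 in a different place: hydrogen in place of 4-cyanophenyl on a saturated chain carbon bound to an aromatic carbon and an aromatic nitrogen. Among the compounds with values here, none of the three measured steps touches this part of the molecule, so no measured step bears directly on the change; they only show that swapping the group on the aromatic carbon moves the number modestly. With no direct guide, the expectation for compound 4 in this assay can only rest on the fact that a sizeable part of the structure is taken away, and a moderately higher number than for compound 3 is expected, a step of a 2.6-fold higher number from compound 3 to compound 4 (0.41 log units; beyond the scatter). For compound 4 in this assay the estimate is 20000 nM, with a range from 5000 nM to 80000 nM.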

Compound 4, half-maximal inhibitory concentration: 5620 nM
For compound 4 the middle estimate is 3.6-fold (0.55 log units) above the measured one, and the stated range covers the measured number.
By their numbers in this assay, from the lowest: compounds 2, 4 and 3 (each within the scatter of the next); then compound 1.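

Replacing the 4-cyanophenyl group with hydrogen on the saturated chain carbon bound to an aromatic carbon and an aromatic nitrogen gives, in this assay, a 1.4-fold lower number from compound 3 to compound 4 (0.14 log units; within the scatter). Within the data shown here, the loss of 8 heavy atoms, including one six-membered aromatic ring of carbon only, therefore leaves two numbers that cannot be told apart, and this is the first reading at this position, since the earlier steps altered only the group on the aromatic carbon of the shared core. With (4-nitrophenoxy)methyl held in place, this pair shows that the 4-cyanophenyl group at this position is not needed to keep the number in this range, though no measurement here explains the result.

The compounds shown leave open whether the same replacement would read the same with cyclohexyl or (4-cyanophenoxy)methyl on the aromatic carbon, as this one pair carries only (4-nitrophenoxy)methyl. They also leave open how a methyl, an amine or a carboxylic acid on that saturated chain carbon would compare with hydrogen and 4-cyanophenyl.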